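Chloro to fluoro on a weakly lethal sulfonamide

A few compounds are considered here, and "the series" means these few. Any claim that something is new, unique, unknown or untested is made for them only; others in the source may bear on it.

Within the data shown here, in a functional assay on cells (leukaemia cell line, Homo sapiens) for inhibition, read by sulforhodamine B assay, with a stated time of 48 h (a lower number here means that less compound is tolerated, a higher number that more compound is tolerated), compound 2 `Cc1cc(Cl)cc(NS(=O)(=O)c2ccc(-c3cnc(C4CC4)o3)cc2)c1` gives 84900 nM, the only actual number measured so far. Compound 1 `O=S(=O)(Nc1cc(F)cc(F)c1)c1ccc(-c2cnc(C3CC3)o2)cc1` stands at > 100000 nM, which is a limit of the assay and not a number. Compound 3 `Cc1cc(F)cc(NS(=O)(=O)c2ccc(-c3cnc(C4CC4)o3)cc2)c1` has not yet been measured. It differs from compound 2 by fluoro in place of chloro on an aromatic carbon, turning 3-chloro-5-methylphenyl into 3-fluoro-5-methylphenyl. Among the measured compounds shown here, one measured step bears on this change: an at least 1.1-fold lower number from compound 1 to compound 2 (0.07 log units; that floor lies within the scatter), with 3-chloro-5-methylphenyl in place of 3,5-difluorophenyl on a sulfonamide nitrogen. With that step in mind, no change beyond the scatter is expected in this assay. The estimated value for compound 3 is 95000 nM, with an expected range from 50000 nM to 170000 nM. This estimate amounts to a 1.1-fold higher number from compound 2 to compound 3 (0.05 log units; within the scatter), an expected step within the scatter.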

Compound 3, concentration lethal to 50% of the cells: 78100 nM
The estimate for compound 3 lay 1.2-fold (0.09 log units) above the measured number; the measured number falls inside the stated range.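

In this assay, fluoro in place of chloro on the aromatic carbon gives a 1.1-fold lower number from compound 2 to compound 3 (0.04 log units; within the scatter); this is the only pair shown with two actual numbers, and it shows that swapping one halogen for the other at this position leaves the number within the scatter. Methyl in place of fluoro gives an at least 1.2-fold lower number from compound 1 to compound 3 (0.10 log units; that floor lies within the scatter), and that floor, like the earlier step, shows no change beyond the scatter. Compound 1 stands at a limit and not a number: the limit of > 100000 nM in this assay, at which 1 of the 3 values shown sits.

The compounds shown carry only fluoro, chloro and methyl on this ring, so it remains open whether an amine, a carboxylic acid or a longer chain at this position would move the number beyond the scatter. Also open, going by these compounds, is whether any compound on the shared core reaches a clearly lower number.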